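The source may hold more compounds than are shown below. What is called first, only, known or untested is meant among the compounds shown, and "the series" means these compounds.

Measured compounds:
- compound 1 `C/C(=N\NC(=S)Nc1ccccc1)c1ccccn1`: 0.18 nM
- compound 2 `C/C(=N/NC(=S)Nc1ccccc1)c1ccccn1`: 0.18 nM

In a functional assay on MCF7 cells (Homo sapiens) for cytotoxicity, read by MTT assay, with a stated time of 48 h (on this read-out higher numbers stand for weaker inhibition and lower numbers for stronger inhibition), compound 1 gives 0.18 nM, and compound 2 gives 0.18 nM. The step of no change at the digits printed from compound 1 to compound 2 (within the scatter) is within the scatter, and the two structures are separated only by the fact that compounds 1 and 2 differ only in the configuration as drawn. Compound 1 therefore stands level with compound 2, and the pair sets a single reference point for this assay.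

Compound 3 `C/C(=N\NC(=S)Nc1ccc([N+](=O)[O-])cc1)c1ccccn1` differs from compound 1 by nitro in place of hydrogen on an aromatic carbon. Among the measured compounds shown here, the one measured step concerns a change of drawn configuration, not a change of substitution on the aromatic ring, so it gives no direct guidance for this step. With no measured substituent change to lean on, the expectation for this assay is a step of no size beyond the scatter, in no preferred direction.

Compound 3 is estimated at 0.22 nM (range 0.06 nM to 1 nM), which means an expected step of a 1.2-fold higher number from compound 1 to compound 3 (0.09 log units; within the scatter).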

Compound 3, half-maximal inhibitory concentration: 52 nM
The estimate for compound 3 lay 240-fold (2.37 log units) below the measured number; measured number outside the range, above it.
By their numbers in this assay, from the lowest: compounds 1 and 2 (each within the scatter of the next); then compound 3.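

Nitro in place of hydrogen gives a 290-fold higher number from compound 1 to compound 3 (2.46 log units; beyond the scatter) in this assay, so this aromatic carbon, para to a large group, is a place where a substitution can move the read-out a long way, here towards weaker inhibition. The earlier step, no change at the digits printed from compound 1 to compound 2 (within the scatter), concerned drawn configuration alone and showed nothing about the aromatic ring. Nothing available gives a reason for the size of the nitro step.

The compounds shown leave open whether this loss belongs to nitro itself or would come with any group at this carbon, such as an amine, a methoxy group or a chlorine atom. They also leave open whether the same step would appear on compound 2, whose drawn configuration differs.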